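The source may hold more compounds than are shown below. What is called first, only, known or untested is meant among the compounds shown, and "the series" means these compounds.

Within the data shown here, compound 2, `CC(C)CC1n2cncc2CN([C@H](C)c2ccc(Cl)cc2)S1(=O)=O`, is one of two compounds measured in an assay on cells for inhibition of cytochrome P450 11B1, mitochondrial (Homo sapiens) (on this read-out lower numbers stand for stronger inhibition and higher numbers for weaker inhibition), where compound 2 gives 204 nM. Compound 1, `CC(C)OCC1n2cncc2CN([C@@H](C)c2ccc(Cl)cc2)S1(=O)=O`, is the nearest of the two, and in this assay compound 1 gives 222 nM; the two values lie within the scatter, so no order between them can be read. Compound 3, `CC(C)CC1n2cncc2CN([C@@H](C)c2ccc(Cl)cc2)S1(=O)=O`, has not been measured. The change from compound 2 to compound 3 is the two compounds have the same atoms and bonds; at least one stereo element is drawn with a configuration in one of them and without one in the other: 1 of 2 stereo elements differ; a stereocentre at a saturated chain carbon is drawn R in compound 2 and S in compound 3; the rest of the molecule is unchanged. Among the measured compounds shown here, no step between two measured compounds shows how a change at this stereocentre acts in this assay, so the direction of the step is open; the values of compound 1 and compound 2 suggest that numbers near this level are reached with more than one arrangement around the core. Compound 3 is therefore expected to sit close to compound 2, with a wide range, as 320 nM between 80 nM and 1500 nM, which means an expected step of a 1.6-fold higher number from compound 2 to compound 3 (0.20 log units; within the scatter).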

Compound 3, half-maximal inhibitory concentration: 76 nM
Compound 3: middle estimate off by 4.2-fold (0.62 log units), on the high side; measured number below the stated range.
By their numbers in this assay, from the lowest: compound 3; then compounds 2 and 1 (each within the scatter of the next).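

In this assay, among these compounds, the stereocentre at the saturated chain carbon now has a readable effect: going from the R to the S drawing gives a 2.7-fold lower number from compound 2 to compound 3 (0.43 log units; beyond the scatter), so configuration at this place matters, which the earlier compounds could not show. With the S drawing held, isopropyl in place of isopropoxy on the saturated chain carbon bound to a saturated ring carbon gives a 2.9-fold lower number from compound 1 to compound 3 (0.47 log units; beyond the scatter), so the side chain counts as well. How far the first step belongs to configuration alone is qualified by one fact about the drawings: the fact that one of compounds 2 and 3 is drawn with a defined configuration and the other without, at the place where they differ.

As far as these compounds go, whether the preference for the S drawing would hold with isopropoxy, a longer chain or an amine on that carbon stays open. From the compounds shown here alone, the role of the second stereo element, which does not differ between the two drawings, also remains open.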